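Aryl replacement at the cyano-flanked position: compound 3 outlook

The source may hold more compounds than are shown below. What is called first, only, known or untested is meant among the compounds shown, and "the series" means these compounds.

Measured so far:
compound 1 `CCOc1nc(-c2cc3ccccc3o2)cc(-c2ccc(OC)cc2)c1C#N`: 204000 nM
compound 2 `CCOc1nc(-c2cc3ccccc3o2)cc(-c2ccc(C)o2)c1C#N`: 417000 nM

In a functional assay on aorta (strain Wistar) for inhibition, with Thoracic aorta (Rattus norvegicus) as the target (a higher number here means a weaker inhibitor, a lower number a stronger inhibitor), compound 2 stands with the highest number of the two; its nearest neighbour is compound 1, separated by a 2.0-fold higher number from compound 1 to compound 2 (0.31 log units; beyond the scatter). Compound 3 `CCOc1nc(-c2cc3ccccc3o2)cc(-c2cn(C)c3ccccc23)c1C#N` differs from compound 2 by 1-methyl-1H-indol-3-yl in place of 5-methylfuran-2-yl on an aromatic carbon. Among the compounds with values here, the only step that bears on this is a 2.0-fold higher number from compound 1 to compound 2 (0.31 log units; beyond the scatter), an aryl swap at the same position with a modest outcome. A similar-sized movement is therefore expected, if any, in this assay, direction uncertain, leaning toward the number of compound 1. Compound 3 is expected at 250000 nM (80000 nM to 800000 nM), an expected step of a 1.7-fold lower number from compound 2 to compound 3 (0.22 log units; within the scatter).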

Compound 3, half-maximal inhibitory concentration: 327000 nM
Estimate against measurement, compound 3: 1.3-fold (0.12 log units) below, within the range that was stated.
By their numbers in this assay, from the lowest: compounds 1, 3 and 2 (each within the scatter of the next, the first and the last beyond it).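

In this assay, 1-methyl-1H-indol-3-yl in place of 5-methylfuran-2-yl gives a 1.3-fold lower number from compound 2 to compound 3 (0.11 log units; within the scatter) and, in place of 4-methoxyphenyl, gives a 1.6-fold higher number from compound 1 to compound 3 (0.20 log units; within the scatter). This position, ortho to a cyano group, therefore accepts the added six-membered aromatic ring without a step beyond the scatter, and compound 3 lies within the scatter of both compound 1 and compound 2. No evidence at hand bears on this result.

From the compounds shown here alone, whether an amine or a carboxylic acid at this position would shift the number stays open, as does any change to the ethoxy group.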